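Swapping methyl for amino on the benzyl ring of compound 1

The compounds below may be only part of what the source reports. "The series", "measured", "known", "first", "only" and "open" are said of these compounds alone.

Compound 1 `COc1ccc(CN(C(=O)CSc2nc3ccccc3s2)c2cc(OC)c(OC)c(OC)c2)cc1C` gives 34300 nM in a functional assay on PC-3 cells (Homo sapiens) for antiproliferative activity, read by MTT assay, with a stated time of 48 h; on this read-out higher numbers stand for weaker inhibition and lower numbers for stronger inhibition. Compound 3 `COc1ccc(CN(C(=O)CSc2nc3ccccc3s2)c2cc(OC)c(OC)c(OC)c2)cc1F` gives 20100 nM in this assay, and the step of a 1.7-fold lower number from compound 1 to compound 3 (0.23 log units; within the scatter) stays within the scatter, so compounds 1 and 3 cannot be told apart. For compound 2 `COc1cc(N(Cc2ccc(Cl)cc2)C(=O)CSc2nc3ccccc3s2)cc(OC)c1OC` this assay reports only a limit, > 80000 nM. The steps of an at least 2.3-fold higher number from compound 1 to compound 2 (0.36 log units; beyond the scatter) and an at least 3.9-fold lower number from compound 2 to compound 3 (0.59 log units; beyond the scatter) exchange the whole benzyl group, so they speak less directly to a single substituent swap.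

Compound 4 `COc1ccc(CN(C(=O)CSc2nc3ccccc3s2)c2cc(OC)c(OC)c(OC)c2)cc1N` differs from compound 1 by amino in place of methyl on an aromatic carbon. Among the measured compounds shown here, the one measured step at the same aromatic carbon, a 1.7-fold lower number from compound 1 to compound 3 (0.23 log units; within the scatter), stayed within the scatter, so compound 4 is expected to show a 1.1-fold lower number from compound 1 to compound 4 (0.06 log units; within the scatter), with no step beyond the scatter. Compound 4 is therefore estimated at 30000 nM, within a range of 12000 nM to 80000 nM.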

Compound 4, half-maximal inhibitory concentration: 7510 nM
Compound 4: the middle estimate sits 4.0-fold (0.60 log units) above what was measured; the measured number lies below the stated range.
By their numbers in this assay, from the lowest: compound 4; then compounds 3 and 1 (each within the scatter of the next). At a limit, above all of these: compound 2.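

At this aromatic carbon the group does matter: amino in place of methyl gives a 4.6-fold lower number from compound 1 to compound 4 (0.66 log units; beyond the scatter), whereas fluoro in place of methyl stayed within the scatter. Amino also stands apart from fluoro in this assay, with a 2.7-fold lower number from compound 3 to compound 4 (0.43 log units; beyond the scatter). Compound 2 has only a limit, so an at least 10-fold lower number from compound 2 to compound 4 (1.02 log units; beyond the scatter) is a bound and not a measured size: the limit of > 80000 nM in this assay, at which 1 of the 4 values shown sits.

On these data alone, whether the amino hydrogens are what counts stays open. A hydroxyl or a dimethylamino group at the same carbon would help to settle that.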